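A few compounds are considered here, and "the series" means these few. Any claim that something is new, unique, unknown or untested is made for them only; others in the source may bear on it.

Series notes. In an assay on SH-SY5Y cells for inhibition of Voltage-dependent N-type calcium channel subunit alpha-1B (Homo sapiens), read by FLIPR and calcium flux, with stated times of 600 s and 300 s, in the presence of a further agent that is not named here (on this read-out lower numbers stand for stronger inhibition and higher numbers for weaker inhibition), compound 3 `CN(Cc1ccc(OCCCN)cc1)c1nc2ccc(Oc3ccc(O)cc3)cc2s1` gives 117000 nM, the highest number among the three measured compounds. Compound 1 `CN(Cc1ccc(OCCCN)cc1)c1nc2ccc(Oc3ccc(F)cc3)cc2s1` gives 98000 nM and compound 2 `CN(Cc1ccc(OCCCN)cc1)c1nc2ccc(Oc3ccccc3)cc2s1` gives 49000 nM. The step of a 1.2-fold higher number from compound 1 to compound 3 (0.08 log units; within the scatter) lies within the scatter, while a 2.4-fold higher number from compound 2 to compound 3 (0.38 log units; beyond the scatter) lies beyond it, and a 2.0-fold lower number from compound 1 to compound 2 (0.30 log units; within the scatter) stays within the scatter.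

Compound 4 `CN(Cc1ccc(OCCCNC(=N)N)cc1)c1nc2ccc(Oc3ccc(O)cc3)cc2s1` differs from compound 3 by a group of 3 heavy atoms (1 carbon, 2 nitrogen; no ring) in place of a hydrogen atom, on an amine nitrogen, that is a group of 3 heavy atoms in place of a hydrogen atom on an amine nitrogen. Among the measured compounds shown here, none of the measured steps touches this amine nitrogen; all three alter a substituent on an aromatic carbon, so no step bears directly on the change. With nothing to lean on, no shift beyond the scatter is expected in this assay, and the expected step is a 1.2-fold lower number from compound 3 to compound 4 (0.07 log units; within the scatter). Compound 4 is estimated at 100000 nM, with a range from 35000 nM to 300000 nM.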

Compound 4, half-maximal inhibitory concentration: 432000 nM
The estimate for compound 4 lay 4.3-fold (0.64 log units) below the measured number; measured number above the stated range.
By their numbers in this assay, from the lowest: compounds 2, 1 and 3 (each within the scatter of the next, the first and the last beyond it); then compound 4.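

Among the compounds shown here, the amine nitrogen, untouched by the earlier steps on aromatic carbons, is not a neutral place for substitution in this assay. Here, the group of 3 heavy atoms (1 carbon, 2 nitrogen; no ring) in place of a hydrogen atom gives a 3.7-fold higher number from compound 3 to compound 4 (0.57 log units; beyond the scatter), towards weaker inhibition. No measurement at hand accounts for this shift.

As far as these compounds go, whether the same change would act alike on compound 1 or compound 2 stays open. So does whether a methyl or acetyl group on this amine nitrogen, or a longer chain leading to it, would move the number as far.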